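A few compounds are considered here, and "the series" means these few. Any claim that something is new, unique, unknown or untested is made for them only; others in the source may bear on it.

compound 1 `Cc1ccc(C(=O)CSC(=S)SC(C)(C)C)cc1`: 31600 nM
compound 2 `CCSC(=S)SCC(=O)c1ccccc1C`: 10000 nM

For the measured compounds named here, in a functional assay on HeLa cells (Homo sapiens) for antiproliferative activity, read by resazurin assay (a higher number here means a weaker inhibitor, a lower number a stronger inhibitor), compound 1 gives 31600 nM, the highest of the two numbers so far and so the weaker inhibitor of the pair. The nearest value belongs to compound 2 at 10000 nM, and that gap lies beyond the scatter. Going by the values given here, no measured pair yet differs in one place only, so the effect of a single change has not been observed.

The next compound is compound 3 `CSC(=S)SCC(=O)c1ccc(C)cc1`, which keeps the core of compound 1. Among the compounds with values here, its one change is methyl in place of tert-butyl on a sulfur whose other neighbour is the thiocarbonyl carbon: methyl in place of tert-butyl on a sulfur.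

The evidence for a direction is thin. Compound 1 stands at the top of the numbers, and compound 2 at 10000 nM shows that a lower number occurs in this small set. In this assay the expected step is a 2.3-fold lower number from compound 1 to compound 3 (0.35 log units; beyond the scatter), toward a lower number and a stronger inhibitor, and only a little beyond the scatter. For compound 3 the estimated value is 14000 nM, with an expected range of 5000 nM to 35000 nM.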

Compound 3, half-maximal inhibitory concentration: 3160 nM
Compound 3: the middle estimate sits 4.4-fold (0.65 log units) above what was measured; measured number outside the range, below it.
By their numbers in this assay, from the lowest: compound 3; then compound 2; then compound 1.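

In this assay, for the compounds shown here, methyl in place of tert-butyl on a sulfur whose other neighbour is the thiocarbonyl carbon gives a 10-fold lower number from compound 1 to compound 3 (1.00 log units; beyond the scatter), the first step that isolates one change and one that lies clearly beyond the scatter. The group on this sulfur therefore matters to the read-out, with the shared core held constant, and the direction runs toward a stronger inhibitor as tert-butyl gives way to methyl. The change involves carbon only: tert-butyl, with 4 heavy atoms, leaves and methyl, with 1 heavy atom, enters, and neither group carries a ring, a hydrogen-bond donor, a hydrogen-bond acceptor or a net charge.

On these data alone, with only these two groups compared on this sulfur, the step gives two end points and no trend, so it remains open how the number behaves for isopropyl, for a longer chain such as n-butyl, or for a chain ending in a carboxylic acid or an amine on the same core. The reason for the step also stays open, as no measurement at hand bears on why this change alters the number.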